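A Nitro Group Joins the Fluorophenyl Ring

This account rests on a few compounds, and the source may have more. Where it says the series, first, only, none or still open, it means among the compounds named here.

In a functional assay for inhibition, with Homo sapiens as the target (on this read-out lower numbers stand for tighter binding and higher numbers for weaker binding), compound 1 `N#Cc1ccc(C2OCC(C/C=C\CCC(=O)O)C(c3cccnc3)O2)cc1` gives 1290 nM and compound 2 `CC(C)(Oc1ccccc1F)C1OCC(C/C=C\CCC(=O)O)C(c2cccnc2)O1` gives 166 nM as the lower of the two numbers, a gap beyond the usual scatter. Compound 3 `CC(C)(Oc1ccc(F)cc1[N+](=O)[O-])C1OCC(C/C=C\CCC(=O)O)C(c2cccnc2)O1` has 4-fluoro-2-nitrophenyl in place of 2-fluorophenyl on an oxygen on a saturated carbon and keeps the rest of compound 2 unchanged. Going by the values given here, no measured pair shows this kind of change, so the expectation starts from compound 2 at 166 nM with no shift beyond the scatter. The estimated 1.1-fold lower number from compound 2 to compound 3 (0.04 log units; within the scatter) is therefore small in this assay and uncertain in direction. Compound 3 is expected at 150 nM within a range from 45 nM to 500 nM on this read-out.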

Compound 3, dissociation constant: 2.51 nM
For compound 3 the middle estimate is 60-fold (1.78 log units) above the measured one; measured number below the stated range.
By their numbers in this assay, from the lowest: compound 3; then compound 2; then compound 1.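

In this assay, the group on an oxygen on a saturated carbon proves highly sensitive: 4-fluoro-2-nitrophenyl in place of 2-fluorophenyl gives a 66-fold lower number from compound 2 to compound 3 (1.82 log units; beyond the scatter) while the rest of the molecule stays the same. The earlier compounds shown here could not show this, as compound 1 and compound 2 differ in more than one place. No available evidence accounts for the size of this step.

As far as these compounds go, the change both adds a nitro group and alters where the fluorine sits, so the contribution of each remains open. From the compounds shown here alone, it is also open how an amine in place of the nitro group would behave.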